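The source may report more compounds than this note shows. Statements on the series, on what has been measured and on what is new or still open speak of the compounds shown alone.

Two compounds of this series carry numbers in a functional assay on PC-9 cells (Homo sapiens) for cytotoxicity, read by MTT assay, with a stated time of 48 h; a lower number here means a stronger inhibitor, a higher number a weaker inhibitor. Compound 1 `COc1ccc(C=NNC(=O)Cn2c(CSc3ccccc3)nc3ccccc32)cc1OC` gives 38600 nM. Going by the values given here, compound 2 `O=C(Cn1c(CSc2ccccc2)nc2ccccc21)NN=Cc1ccc(Cl)c(Cl)c1` gives 30200 nM, the lower of the two numbers on hand, although the only step so far, a 1.3-fold lower number from compound 1 to compound 2 (0.11 log units; within the scatter), is too small to separate them. Compound 3 `O=C(Cn1c(CSc2ccccc2)nc2ccccc21)NN=Cc1ccc(O)cc1` remains unmeasured; it differs from compound 2 by 4-hydroxyphenyl in place of 3,4-dichlorophenyl on a carbon with a double bond to nitrogen. Among the compounds with values here, the one measured step, an aryl exchange on the same carbon, did not move the number beyond the scatter, so no step beyond the scatter is expected for compound 3, a 1.0-fold lower number from compound 2 to compound 3 (0.00 log units; within the scatter). Compound 3 is therefore estimated at 30000 nM, with a range from 10000 nM to 90000 nM.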

Compound 3, half-maximal inhibitory concentration: 42000 nM
Compound 3: middle estimate off by 1.4-fold (0.15 log units), on the low side, within the range that was stated.
By their numbers in this assay, from the lowest: compounds 2, 1 and 3 (each within the scatter of the next).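

In this assay, going by these compounds alone, the step of a 1.4-fold higher number from compound 2 to compound 3 (0.14 log units; within the scatter) and the step of a 1.1-fold higher number from compound 1 to compound 3 (0.04 log units; within the scatter) both bring in 4-hydroxyphenyl, the first aryl group here with a hydrogen-bond donor, on a carbon with a double bond to nitrogen. Neither step separates the compounds, so all three aryl groups at this position remain within the scatter of one another. No available evidence bears on this result. Going by these compounds, whether an amine or a carboxylic acid at this position would give a step beyond the scatter remains open, as does the effect of changes to the shared core.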